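Working notes: fluoro in place of nitro

This account rests on a few compounds, and the source may have more. Where it says the series, first, only, none or still open, it means among the compounds named here.

Three compounds share the core so far. In an ADME assay on Vero cells (Chlorocebus sabaeus) for cytotoxicity, read by MTT assay, with a stated time of 72 h (on this read-out higher numbers stand for an effect only at larger amounts of compound and lower numbers for an effect already at smaller amounts), compound 1 `Cc1cccc(C(=O)Nc2nc(-c3ccccn3)cs2)c1` gives 4100 nM. In the same read-out compound 2 `COc1ccccc1C(=O)Nc1nc(-c2ccccn2)cs1` gives 43500 nM, so these two values lie well apart, with compound 2 showing its effect only at the larger amount. Compound 3 `O=C(Nc1nc(-c2ccccn2)cs1)c1cccc([N+](=O)[O-])c1` has no place on this scale: its entry in this assay reads "not determined" (no result reported), with no result reported.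

The next compound to be measured is compound 4 `O=C(Nc1nc(-c2ccccn2)cs1)c1cccc(F)c1`. The structural change is fluoro in place of nitro on an aromatic carbon, meta to a large group.

Going by the values given here, with no number for compound 3 and no measured step, neither the size nor the direction of this change can be stated, and no step is expected in any particular direction. Among the compounds with values here, the only guide is the span of the two measured neighbours, compound 1 at 4100 nM and compound 2 at 43500 nM, and compound 4 is expected to fall inside or close to that span.

For compound 4 the estimated value in this assay is 12000 nM, with an expected range of 3000 nM to 50000 nM.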

Compound 4, half-maximal effective concentration: 1200 nM
Beside the measured number, compound 4's estimate is 10-fold (1.00 log units) above it; measured number outside the range, below it.
By their numbers in this assay, from the lowest: compound 4; then compound 1; then compound 2.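

In this assay the aromatic carbon meta to a large group now has its first readable step: fluoro in place of methyl gives a 3.4-fold lower number from compound 1 to compound 4 (0.53 log units; beyond the scatter), so the group on this carbon changes the number by more than the usual scatter, with the smaller value on the fluoro side. The change from nitro to fluoro cannot be read, as compound 3 has no result in this assay, and the nitro group therefore has no measured standing relative to either fluoro or methyl. No measurement at hand accounts for the step from methyl to fluoro.

As far as these compounds go, one step between two groups gives a comparison and not a trend, so it remains open how the number would respond to other groups on this same carbon, such as chlorine, an amine, a carboxylic acid or a longer chain. Also open, from the compounds shown here alone, is whether fluoro in place of methyl would give a step of similar size and direction on other carbons of this aromatic ring.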